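The compounds below may be only part of what the source reports. "The series", "measured", "known", "first", "only" and "open" are said of these compounds alone.

Working notes on the series. Compound 1 `CC1(C)C[C@@H](CN([C@H](CCC(F)(F)F)C(N)=O)S(=O)(=O)c2ccc(Cl)cc2)O1` gives 16.5 mL/min/kg in an in vitro ADME assay on microsomes from liver (Homo sapiens) for metabolic stability, read by HPLC; on this read-out higher numbers stand for fast clearance and lower numbers for slow clearance. Compound 2 `NC(=O)[C@@H](CCC(F)(F)F)N(CC1CCCC1)S(=O)(=O)c1ccc(Cl)cc1` gives 229 mL/min/kg in this assay. For compound 3 `NC(=O)[C@@H](CCC(F)(F)F)N(C[C@H]1CCCCO1)S(=O)(=O)c1ccc(Cl)cc1` this assay reports only a limit, > 300 mL/min/kg; compound 3 therefore sits at the limit of > 300 mL/min/kg in this assay, at which 1 of the 3 values shown sits. The steps of a 14-fold higher number from compound 1 to compound 2 (1.14 log units; beyond the scatter) and an at least 18-fold higher number from compound 1 to compound 3 (1.25 log units; beyond the scatter) are large; an at least 1.3-fold higher number from compound 2 to compound 3 (0.11 log units; that floor lies within the scatter) lies within the scatter. Compound 4 `NC(=O)[C@@H](CCC(F)(F)F)N(C[C@@H]1COCCO1)S(=O)(=O)c1ccc(Cl)cc1` differs from compound 3 by 1,4-dioxan-2-yl in place of oxan-2-yl on a saturated chain carbon bound to a sulfonamide nitrogen. Within the data shown here, no measured step makes this exchange; the steps that reach compound 3 only place it at the limit, so the size of the step is uncertain. The expected step is an at least 1.6-fold lower number from compound 3 to compound 4 (0.22 log units; that floor lies within the scatter), a moderate fall rather than none. Compound 4 is estimated at 180 mL/min/kg, within a range from 60 mL/min/kg to 300 mL/min/kg.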

Compound 4, clearance: 117 mL/min/kg
Compound 4: the middle estimate sits 1.5-fold (0.19 log units) above what was measured; low and high end bracket the measured number.
By their numbers in this assay, from the lowest: compound 1; then compounds 4 and 2 (each within the scatter of the next). At a limit, above all of these: compound 3.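

Compound 3 is only a limit of the assay, not a number: the limit of > 300 mL/min/kg in this assay, at which 1 of the 4 values shown sits. Even so, 1,4-dioxan-2-yl in place of oxan-2-yl gives an at least 2.5-fold lower number from compound 3 to compound 4 (0.40 log units; beyond the scatter), so a six-membered ring at this place can stand clear of that limit. In place of cyclopentyl the same group gives a 2.0-fold lower number from compound 2 to compound 4 (0.29 log units; within the scatter), and in place of 4,4-dimethyloxetan-2-yl it gives a 7.1-fold higher number from compound 1 to compound 4 (0.85 log units; beyond the scatter), which leaves compound 1 the lowest of the series. On these data alone, whether morpholin-2-yl, a ring amine in place of the second oxygen, would lower the number further stays open. So does whether an unsubstituted oxetan-2-yl would stand with compound 1 or with compound 4.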